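The source may report more compounds than this note shows. Statements on the series, on what has been measured and on what is new or still open speak of the compounds shown alone.

Measured in an ADME assay on CHO cells (Cricetulus griseus) for cytotoxicity; a higher number here means a weaker inhibitor, a lower number a stronger inhibitor:
- Compound 1 `N#Cc1cc(=O)[nH]c(=O)n1[C@@H]1O[C@H](CO)[C@@H](O)[C@H]1O`: > 1500000 nM, a limit
- Compound 2 `[N-]=[N+]=Nc1cc(=O)[nH]c(=O)n1[C@@H]1O[C@H](CO)[C@@H](O)[C@H]1O`: > 1500000 nM, a limit

Compound 2 has no number in this assay, only the limit of > 1500000 nM. The next compound, compound 3 `Nc1cc(=O)[nH]c(=O)n1[C@@H]1O[C@H](CO)[C@@H](O)[C@H]1O`, carries amino in place of azido on an aromatic carbon.

Going by the values given here, only one measured step bears on this change. That step, a step that the two limits leave unreadable from compound 1 to compound 2, puts azido in place of cyano on an aromatic carbon, at the same place on the core, and gives no size to build on. Compound 1 and compound 2 share one ceiling, and no step beyond the scatter is expected for compound 3 because of the limit of > 1500000 nM in this assay, at which 2 of the 2 values shown sit. The expected step is a number no higher from compound 2 to compound 3 (the limit leaves the size open). Compound 3 will most likely be reported as a limit again. As a number, the estimate for compound 3 is 1500000 nM, with an expected range of 600000 nM to 2500000 nM.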

Compound 3, half-maximal inhibitory concentration: > 1500000 nM
Compound 3 was reported as a limit; the forecaster's own chance of this, stated with the estimate: 85%; the middle value sits exactly at the limit.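

In this assay, going by these compounds alone, compound 1, compound 2 and compound 3 are all reported only as limits, and no step among them can be read. The compounds shown leave open whether cyano, azido and amino differ at all in this assay, with none of the three giving a number.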